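Swapping one aryl group for another on the amine nitrogen

The source may hold more compounds than are shown below. What is called first, only, known or untested is meant among the compounds shown, and "the series" means these compounds.

Compound 1: `CCCCCCNc1nc(SCc2ccc(C(F)(F)F)cc2)nc2ccccc12`, 19000 nM
Compound 2: `CCCCCCCCNc1nc(SCc2ccc(C(F)(F)F)cc2)nc2ccccc12`, 10500 nM
Compound 3: `FC(F)(F)c1ccc(CSc2nc(Nc3cccc(Cl)c3)c3ccccc3n2)cc1`, 13400 nM

All three share one core and differ only in the group on the amine nitrogen. In a functional assay on PC-3 cells (Homo sapiens) for cytotoxicity, read by MTT assay, with a stated time of 72 h (on this read-out lower numbers stand for stronger inhibition and higher numbers for weaker inhibition), compound 3 gives 13400 nM. Its number sits within the scatter of both neighbours: the step of a 1.4-fold lower number from compound 1 to compound 3 (0.15 log units; within the scatter) and the step of a 1.3-fold higher number from compound 2 to compound 3 (0.11 log units; within the scatter) are each too small to count as real change, as is a 1.8-fold lower number from compound 1 to compound 2 (0.26 log units; within the scatter) between the two alkyl analogues.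

Compound 4, `FC(F)(F)c1ccc(CSc2nc(Nc3ccc(C(F)(F)F)cc3)c3ccccc3n2)cc1`, has not yet been measured. It carries the change (4-(trifluoromethyl)phenyl in place of 3-chlorophenyl on a nitrogen on an aromatic ring). Going by the values given here, no measured step exchanges one aryl group for another on this nitrogen; the closest precedents, the aryl-for-alkyl exchanges from compound 1 and compound 2 to compound 3, stayed within the scatter. So the expectation for this assay is a step of no clear size in either direction. Compound 4 is therefore estimated at 13000 nM, within a range from 5000 nM to 35000 nM, which means an expected step of a 1.0-fold lower number from compound 3 to compound 4 (0.01 log units; within the scatter).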

Compound 4, half-maximal inhibitory concentration: 7880 nM
The estimate for compound 4 lay 1.6-fold (0.22 log units) above the measured number; the range from low to high includes it.
By their numbers in this assay, from the lowest: compounds 4, 2, 3 and 1 (each within the scatter of the next, the first and the last beyond it).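

In this assay, exchanging one aryl group for another on this nitrogen stays within the scatter (a 1.7-fold lower number from compound 3 to compound 4 (0.23 log units; within the scatter)), as does putting 4-(trifluoromethyl)phenyl in place of octyl (a 1.3-fold lower number from compound 2 to compound 4 (0.12 log units; within the scatter)). Going by these compounds alone, only 4-(trifluoromethyl)phenyl in place of hexyl passes beyond the scatter, and modestly (a 2.4-fold lower number from compound 1 to compound 4 (0.38 log units; beyond the scatter)), making this the first pair in the set that the group on the nitrogen clearly separates. No measurement here accounts for that separation.

The two aryl groups differ in both the substituent and its printed ring number, so the compounds shown cannot tell these two changes apart; 4-chlorophenyl would bear on that. Also open, as far as these compounds go, is how a phenyl ring carrying an amine or a carboxylic acid, or a chain longer than octyl, would compare on this nitrogen.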